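Swapping the Six-Membered Diazine on a Fused Core

The source may report more compounds than this note shows. Statements on the series, on what has been measured and on what is new or still open speak of the compounds shown alone.

Compound 2 `Fc1ccc2nc(-c3cnccn3)n(C3CC3)c2c1` holds the lowest of the two numbers in an assay on cells for inhibition of cytochrome P450 11B2, mitochondrial (Homo sapiens), read by HPLC, with a stated time of 90 min (on this read-out higher numbers stand for weaker inhibition and lower numbers for stronger inhibition), giving 541 nM. Compound 1 `Fc1ccc2nc(-c3cn[nH]c3)n(C3CC3)c2c1` gives 782 nM in this assay, and the step of a 1.4-fold lower number from compound 1 to compound 2 (0.16 log units; within the scatter) stays within the scatter. Compound 3 `Fc1ccc2nc(-c3ccnnc3)n(C3CC3)c2c1` differs from compound 2 by pyridazin-4-yl in place of pyrazin-2-yl on an aromatic carbon. Going by the values given here, the only measured step, an exchange of the aromatic ring at the same place, lay within the scatter, so this further exchange of one six-membered aromatic ring with 2 hetero atoms for another is expected to give no step beyond the scatter, a 1.1-fold higher number from compound 2 to compound 3 (0.04 log units; within the scatter). Compound 3 is therefore estimated at 600 nM, with a range from 200 nM to 1800 nM.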

Compound 3, half-maximal inhibitory concentration: 330 nM
The estimate for compound 3 lay 1.8-fold (0.26 log units) above the measured number; measured number inside the range.
By their numbers in this assay, from the lowest: compounds 3, 2 and 1 (each within the scatter of the next, the first and the last beyond it).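

In this assay, going by these compounds alone, pyridazin-4-yl in place of 1H-pyrazol-4-yl on this aromatic carbon gives the first step at this position to pass the scatter, though only a modest one (a 2.4-fold lower number from compound 1 to compound 3 (0.37 log units; beyond the scatter)). The change between the two six-membered rings stays within the scatter (a 1.6-fold lower number from compound 2 to compound 3 (0.21 log units; within the scatter)), so the numbers do not separate pyrazin-2-yl from pyridazin-4-yl here. Nothing measured on these compounds accounts for either step. Still open, from the compounds shown here alone, is how a pyridin-4-yl ring with a single ring nitrogen, or an amine, would read at this carbon. Going by these compounds, a longer alkyl chain in place of the cyclopropyl group also remains open.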